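Notes on the step from compound 3 to compound 4

The compounds below may be only part of what the source reports. "The series", "measured", "known", "first", "only" and "open" are said of these compounds alone.

Three compounds carry numbers. In a functional assay on MCF7 cells (Homo sapiens) for cytotoxicity, read by MTT assay, with a stated time of 72 h (on this read-out lower numbers stand for stronger inhibition of growth and higher numbers for weaker inhibition of growth), compound 1 `CCCCC[Se]c1nc(N)c2ccccc2n1` gives 28600 nM, compound 2 `CSc1nc(NCCCCCO)c2ccccc2n1` gives 62000 nM, and compound 3 `CCCCC[Se]c1nc([Se]CCCCC)c2ccccc2n1` gives 38400 nM. Compound 3 stands second highest of the three, yet its gaps to compound 1 and to compound 2 both lie within the scatter, so no order among them can be read.

Compound 4 `CCCCC[Se]c1nc(NCc2ccccc2)c2ccccc2n1` differs from compound 3 in one place: a group of 8 heavy atoms (7 carbon, 1 nitrogen; one six-membered aromatic ring of carbon only) in place of a group of 6 heavy atoms (5 carbon, 1 selenium; no ring), on an aromatic carbon.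

Within the data shown here, the one measured step that bears on an exchange at this position is a 1.3-fold higher number from compound 1 to compound 3 (0.13 log units; within the scatter), which stayed within the scatter. Compound 2, carrying an amine with a chain, also sits within the scatter of compound 3. The expected step of a 1.2-fold lower number from compound 3 to compound 4 (0.08 log units; within the scatter) in this assay is therefore none beyond the scatter. Compound 4 is expected at 32000 nM, between 10000 nM and 100000 nM.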

Compound 4, concentration for 50% growth inhibition: 50 nM
Estimate against measurement, compound 4: 640-fold (2.81 log units) above, and the stated range ends above it.
By their numbers in this assay, from the lowest: compound 4; then compounds 1, 3 and 2 (each within the scatter of the next, the first and the last beyond it).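

In this assay, among these compounds, this position proves far more responsive than the earlier compounds showed, with benzylamino in place of the selenium-bearing chain (a 770-fold lower number from compound 3 to compound 4 (2.89 log units; beyond the scatter)). Benzyl on the nitrogen is the only difference from the free amine (a 570-fold lower number from compound 1 to compound 4 (2.76 log units; beyond the scatter)), so the amine alone does not give this strength. No data shown here explain the size of the change.

From the compounds shown here alone, it remains open whether the aromatic ring is required, since a cyclohexylmethylamino group would test that. A phenethylamino group would show whether the length of the link matters.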